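From Ester to Dichlorophenyl on the Shared Core

A few compounds are considered here, and "the series" means these few. Any claim that something is new, unique, unknown or untested is made for them only; others in the source may bear on it.

Compound 1 `C=C[C@@](C)(/C=C/c1ccc(O)c(C=O)c1)CCC=C(C)C` carries a formyl group on an aromatic carbon, where compound 2 `C=C[C@@](C)(/C=C/c1ccc(O)c(/C=C/C(=O)OCC)c1)CCC=C(C)C` has 2-(ethoxycarbonyl)ethenyl and compound 3 `C=C[C@@](C)(/C=C/c1ccc(O)c(/C=C(\C)C(=O)OCC)c1)CCC=C(C)C` has 2-(ethoxycarbonyl)prop-1-en-1-yl. In a functional assay on Jurkat cells (Homo sapiens) for cytotoxicity, with a stated time of 72 h (a lower number here means that less compound is needed, a higher number that more compound is needed for the effect), compound 1 gives > 49000 nM, which is a limit and not a number. Compound 2 gives > 49000 nM, likewise a limit. Compound 3 gives > 49000 nM, again a limit. Compound 2 therefore has no exact position, and the whole set offers only (the limit of > 49000 nM in this assay, at which 3 of the 3 values shown sit).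

Compound 4 `C=C[C@@](C)(/C=C/c1ccc(O)c(/C=C/c2ccc(Cl)c(Cl)c2)c1)CCC=C(C)C` has 3,4-dichlorophenyl in place of ethoxycarbonyl on a double-bonded chain carbon bound to a double-bonded chain carbon. The nearest measured changes are a step that the two limits leave unreadable from compound 1 to compound 2, a step that the two limits leave unreadable from compound 1 to compound 3 and a step that the two limits leave unreadable from compound 2 to compound 3. None gives a size to carry over, and none of these compounds tests the new group. A modest move towards less compound needed in this assay is only a cautious expectation, and a further limit remains quite possible. The expected change is an at least 1.6-fold lower number from compound 2 to compound 4 (0.21 log units; that floor lies within the scatter). The estimated value for compound 4 is 30000 nM, with an expected range from 10000 nM to 60000 nM.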

Compound 4, half-maximal effective concentration: > 49000 nM
Compound 4 was reported as a limit; the forecaster's own chance of this, stated with the estimate: 50%; middle value at least 1.6-fold (0.21 log units) away from the limit.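

Compound 2 and compound 4 are both reported only as limits, so no size can be read for the change between them. Still open is what concentration in this assay gives the effect for any of these compounds, as the set holds only this: the limit of > 49000 nM in this assay, at which 4 of the 4 values shown sit.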